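Swapping one group on compound 1

A few compounds are considered here, and "the series" means these few. Any claim that something is new, unique, unknown or untested is made for them only; others in the source may bear on it.

compound 1 `COc1cccc(/C=C/C(=O)/C=C/c2ccc(OCc3cn(CCCCOc4cc(=O)oc5ccccc45)nn3)c(OC)c2)c1` gives "not active" (no number reported)
compound 2 `COc1cc(/C=C/C(=O)/C=C/c2cc(OC)c(OC)c(OC)c2)ccc1OCc1cn(CCOc2cc(=O)oc3ccccc23)nn1` gives 22%

In a functional assay on PC-3 cells (Homo sapiens) for inhibition, read by sulforhodamine B assay, with a stated time of 48 h, tested at 50 uM (a higher number here means more inhibition of growth at the concentration tested, a lower number less inhibition of growth), compound 1 reads "not active" (no number reported) and so offers no number to start from. Compound 3 `COc1cc(/C=C/C(=O)/C=C/c2cc(OC)c(OC)c(OC)c2)ccc1OCc1cn(CCCCOc2cc(=O)oc3ccccc23)nn1` changes one group, counted as 3,4,5-trimethoxyphenyl in place of 3-methoxyphenyl on a double-bonded chain carbon bound to a double-bonded chain carbon in all: 3,4,5-trimethoxyphenyl in place of 3-methoxyphenyl on a double-bonded chain carbon bound to a double-bonded chain carbon. Compound 2 also carries 3,4,5-trimethoxyphenyl and gives 22% here, so a modest upward step in this assay is expected. The expected value for compound 3 is 20% within a range of 5% to 40% in this estimate.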

Compound 3, percent growth inhibition at one concentration: 5%
For compound 3 the middle estimate is 15 percentage points above the measured one; the range from low to high includes it.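

Among the compounds shown here, compound 1 gives "not active" (no number reported) and compound 3 gives 5% so no step between compound 1 and compound 3 can be read. How far 3,4,5-trimethoxyphenyl in place of 3-methoxyphenyl shifts growth inhibition stays open, and no evidence here bears on a cause.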